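Hexyloxy in place of benzyloxy on the shared core

A few compounds are considered here, and "the series" means these few. Any claim that something is new, unique, unknown or untested is made for them only; others in the source may bear on it.

Measured in a functional assay on HepG2 cells (Homo sapiens) for cytotoxicity, read by MTT assay, with a stated time of 48 h; on this read-out higher numbers stand for weaker inhibition and lower numbers for stronger inhibition:
compound 1 `CN(C)CCNc1ccnc2cc(OCc3ccccc3)ccc12` gives 3120 nM
compound 2 `Clc1ccnc2cc(OCc3ccccc3)ccc12` gives 2680 nM
compound 3 `Fc1ccc(COc2ccc3c(Cl)ccnc3c2)cc1` gives 3010 nM

Compound 1 carries the largest of the three numbers shown, yet compound 3, its nearest neighbour, and compound 2, its furthest, both sit within the scatter of it, so the three cannot be told apart on this read-out. The two known steps are a 1.2-fold lower number from compound 1 to compound 2 (0.07 log units; within the scatter), chloro in place of (2-(dimethylamino)ethyl)amino on an aromatic carbon, and a 1.1-fold higher number from compound 2 to compound 3 (0.05 log units; within the scatter), fluoro in place of hydrogen on an aromatic carbon. Both lie within the scatter.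

Compound 4 `CCCCCCOc1ccc2c(NCCN(C)C)ccnc2c1` differs from compound 1 by pentyl in place of phenyl on a saturated chain carbon bound to an oxygen on an aromatic ring; cut one bond further out, this reads benzyl to hexyl, or benzyloxy to hexyloxy. For the measured compounds named here, no measured step touches this part of the molecule: the two steps that are known alter other parts of the structure, and each stays within the scatter. The series gives no basis for a direction here, and the expected step is therefore none beyond the scatter, a 1.0-fold lower number from compound 1 to compound 4 (0.02 log units; within the scatter). On these data alone, compound 4 is accordingly estimated at 3000 nM, with a range from 1400 nM to 6500 nM, the width of the range reflecting that the change itself is untested in this set.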

Compound 4, half-maximal inhibitory concentration: 1370 nM
Estimate against measurement, compound 4: 2.2-fold (0.34 log units) above; the measured number lies below the stated range.
By their numbers in this assay, from the lowest: compounds 4, 2, 3 and 1 (each within the scatter of the next, the first and the last beyond it).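

For the compounds shown here, the benzyloxy position is the only place so far where a single change goes beyond the scatter: in this assay, hexyloxy in place of benzyloxy gives a 2.3-fold lower number from compound 1 to compound 4 (0.36 log units; beyond the scatter), while the two earlier steps, made elsewhere on the molecule, stayed within it. The number therefore responds to what stands at this position, though the step is modest. With (2-(dimethylamino)ethyl)amino held in place, phenyl can give way to pentyl, losing the six-membered aromatic ring of carbon only, without the number rising, so in this pair that ring is not needed to keep the measured cytotoxicity; nothing at hand accounts for the step.

The comparison changes chain and ring together, so butyloxy or octyloxy would test the dependence on chain length, and cyclohexylmethoxy would separate the loss of aromaticity from the loss of the ring itself. On these data alone, it also remains open whether hexyloxy gives a step of the same direction on the chloro compounds, as it is seen here only with (2-(dimethylamino)ethyl)amino on the shared core.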